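A few compounds are considered here, and "the series" means these few. Any claim that something is new, unique, unknown or untested is made for them only; others in the source may bear on it.

Compound 2 `COC(=O)C1=C(C)N=C(C)/C(=C(\O)OC)C1c1cc(Cl)cc(Cl)c1` gives 93.3 nM in a functional assay (muscle tissue) with Cavia porcellus as the target (on this read-out lower numbers stand for an effect already at smaller amounts and higher numbers for an effect only at larger amounts of compound), the lowest of the three numbers measured, although compound 3 `CCOc1ccccc1C1C(C(=O)OC)=C(C)N=C(C)/C1=C(\O)OC` at 110 nM lies within the scatter of it, and only compound 1 `COC(=O)C1=C(C)N=C(C)/C(=C(\O)OC)C1c1cccc(OC)c1` at 191 nM stands beyond it. Among the compounds with values here, the single step that reaches compound 2, a 2.0-fold lower number from compound 1 to compound 2 (0.31 log units; beyond the scatter), came from exchanging the aryl group on the saturated ring carbon. Compound 4 `COC(=O)C1=C(C)N=C(C)/C(=C(\O)OC)C1c1ccccc1F` makes a change of the same kind: 2-fluorophenyl in place of 3,5-dichlorophenyl on a saturated ring carbon. Compound 3 differs from compound 2 only in that aryl group, and the two numbers fall within the scatter of each other, so such an exchange need not move the read-out. Compound 4 is therefore expected to give 140 nM (range 60 nM to 330 nM) in this assay, an expected step of a 1.5-fold higher number from compound 2 to compound 4 (0.18 log units; within the scatter), within or near the scatter.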

Compound 4, half-maximal effective concentration: 42.7 nM
Beside the measured number, compound 4's estimate is 3.3-fold (0.52 log units) above it, outside the stated range (below it).
By their numbers in this assay, from the lowest: compound 4; then compounds 2, 3 and 1 (each within the scatter of the next, the first and the last beyond it).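

In this assay, the 2-fluorophenyl group on the saturated ring carbon stands apart from all three other aryl groups shown, with a 2.2-fold lower number from compound 2 to compound 4 (0.34 log units; beyond the scatter), a 2.6-fold lower number from compound 3 to compound 4 (0.41 log units; beyond the scatter) and a 4.5-fold lower number from compound 1 to compound 4 (0.65 log units; beyond the scatter). The closeness of compound 2 and compound 3 therefore did not mean that this position is flat: an aryl exchange here can move the read-out beyond the scatter. No evidence on hand accounts for this step. Still open, from the compounds shown here alone, is whether the fluoro group itself or its place on the phenyl group carries the step, and how a phenyl group bearing an amine or a carboxylic acid would read.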